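The source may report more compounds than this note shows. Statements on the series, on what has been measured and on what is new or still open speak of the compounds shown alone.

Compound 1 `O=C(NCc1ccc(S(=O)(=O)c2cc(F)cc(F)c2)cc1)c1cc2cnccc2[nH]1` gives 82% in an ADME assay on microsomes from liver (Homo sapiens) for metabolic stability, read by LC-MS, with a stated time of 30 min, tested at 1 uM; on this read-out higher numbers stand for a more stable compound and lower numbers for a less stable compound. Compound 2 `O=C(NCc1ccc(S(=O)(=O)c2cc(F)cc(F)c2)cc1)c1cnc2nccn2c1` differs from it by a group of 9 heavy atoms (6 carbon, 3 nitrogen; one five-membered aromatic ring with 2 hetero atoms, one six-membered aromatic ring with 2 hetero atoms) in place of a group of 9 heavy atoms (7 carbon, 2 nitrogen; one five-membered aromatic ring with 1 hetero atom, one six-membered aromatic ring with 1 hetero atom), on a carbonyl carbon; in this assay compound 2 gives 78%, a step of a number 4 percentage points lower from compound 1 to compound 2 (within the scatter). Compound 3 `O=C(NCc1ccc(S(=O)(=O)c2ccccc2)cc1)c1cc2cnccc2[nH]1` differs from compound 1 by phenyl in place of 3,5-difluorophenyl on a sulfonyl sulfur; in this assay compound 3 gives 75%, a step of a number 7 percentage points lower from compound 1 to compound 3 (within the scatter). Compound 4 `O=C(NCc1ccc(S(=O)(=O)c2ccccc2)cc1)c1cnc2nccn2c1` has not yet been measured. It differs from compound 3 by a group of 9 heavy atoms (6 carbon, 3 nitrogen; one five-membered aromatic ring with 2 hetero atoms, one six-membered aromatic ring with 2 hetero atoms) in place of a group of 9 heavy atoms (7 carbon, 2 nitrogen; one five-membered aromatic ring with 1 hetero atom, one six-membered aromatic ring with 1 hetero atom), on a carbonyl carbon, the same change as that between compound 1 and compound 2, made on a carbonyl carbon whose other neighbour is again an amide-type nitrogen. Resting on the step of a number 4 percentage points lower from compound 1 to compound 2 (within the scatter), which stayed within the scatter, compound 4 is expected to show a step of like size, a number 3 percentage points lower from compound 3 to compound 4 (within the scatter). Compound 4 is therefore estimated to give 72% in this assay, with a likely range from 60% to 84%.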

Compound 4, percent of the compound remaining: 60%
Beside the measured number, compound 4's estimate is 12 percentage points above it; the range from low to high includes it.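

On the core of compound 3, the exchange on the carbonyl carbon gave a number 15 percentage points lower from compound 3 to compound 4 (beyond the scatter), and this step cannot be told apart in size from the one on the core of compound 1: the same change on two cores in this assay, a number 4 percentage points lower (within the scatter) from compound 1 to compound 2 and a number 15 percentage points lower (beyond the scatter) from compound 3 to compound 4, 11 percentage points apart, within the scatter of two such steps

On the core of compound 2, phenyl in place of 3,5-difluorophenyl on the sulfonyl sulfur gave a number 18 percentage points lower from compound 2 to compound 4 (beyond the scatter), and again the two steps cannot be told apart in size: the same change on two cores in this assay, a number 7 percentage points lower (within the scatter) from compound 1 to compound 3 and a number 18 percentage points lower (beyond the scatter) from compound 2 to compound 4, 11 percentage points apart, within the scatter of two such steps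

Among the compounds shown here, the compounds thus show no difference in size for either change between cores, yet with only one pair on each core they neither prove nor exclude that the size depends on the core.

On these data alone, it remains open whether other groups on the sulfonyl sulfur, such as a methoxyphenyl or a chlorophenyl, would behave alike. The same holds for an amine or a longer chain on the carbonyl carbon.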